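The compounds below may be only part of what the source reports. "The series", "measured", "known", "first", "only" and "open" are said of these compounds alone.

Compound 1 has the structure `O=C(O)CCCOc1ccc(-c2nc3ncccn3c2NC2CCCCC2)cc1`. In a toxicity assay on A549 cells (Homo sapiens) for cytotoxicity, read by luminescence and CellTiter-Glo, with a stated time of 48 h (on this read-out higher numbers stand for lower toxicity in this test and lower numbers for higher toxicity in this test), compound 1 gives > 100000 nM, which is a limit of the assay rather than a number. Compound 2 has the structure `CCOC(=O)CCCOc1ccc(-c2nc3ncccn3c2NC2CCCCC2)cc1`. In this assay compound 2 gives > 100000 nM, again a limit. Compound 3 has the structure `COCCCCOc1ccc(-c2nc3ncccn3c2NC2CCCCC2)cc1`. In this assay compound 3 gives 100000 nM.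

Compound 3 therefore stands as the only one of the three with a number; the other two sit at the limit of > 100000 nM in this assay, at which 2 of the 3 values shown sit. The unmeasured compound 4 has the structure `COCCOc1ccc(-c2nc3ncccn3c2NC2CCCCC2)cc1`. It differs from compound 3 in one place: methoxy in place of 2-methoxyethyl on a saturated chain carbon, two bonds along the chain from an oxygen on an aromatic ring. Of the measured steps, the two that change the far end of the same chain bear on this: a number no higher from compound 1 to compound 3 (the limit leaves the size open) and a number no higher from compound 2 to compound 3 (the limit leaves the size open), neither of which has a readable size. The remaining step, a step that the two limits leave unreadable from compound 1 to compound 2, is also not readable. Nothing among these steps shows a change beyond the scatter for altering this chain, so no step beyond the scatter is expected here, and the step that this estimate means is no change at the digits printed from compound 3 to compound 4 (within the scatter). Compound 4 is expected to give about 100000 nM in this assay, with a range from 50000 nM to 200000 nM.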

Compound 4, half-maximal cytotoxic concentration: > 100000 nM
Compound 4: only a limit was reported; the forecaster's own chance of this, stated with the estimate: 60%; the middle value lies on the limit itself.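

In this assay, compound 4 gives > 100000 nM, which is a limit of the assay and not a number. Cutting 4-methoxybutoxy back to 2-methoxyethoxy thus gives a number no lower from compound 3 to compound 4 (the limit leaves the size open), the first look at a change in chain length rather than in the group at the far end of the chain, and the shorter chain brings no sign of a lower number. The steps to compound 4 from compound 1 and from compound 2 cannot be read, as both ends of each are limits, and compound 3 remains the only compound with a number: the limit of > 100000 nM in this assay, at which 3 of the 4 values shown sit.

The compounds shown leave open how far above the limit compound 4 lies, and so how large the step from compound 3 really is. They also leave open whether an amine at the end of the chain, or a chain longer than 4-methoxybutyl, would give a number clearly lower in this assay.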